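Swapping an Imidazole for an Amide Chain

The compounds below may be only part of what the source reports. "The series", "measured", "known", "first", "only" and "open" are said of these compounds alone.

Compound 2 `Cc1nc(C(c2ccc(-c3ccc4cccc(F)c4c3)[nH]c2=O)C(C)C)[nH]c1C` stands at the lower of the two numbers seen so far: in an assay on CHO cells for displacement of a labelled ligand from prostaglandin E2 receptor EP3 subtype (Homo sapiens), read by radioligand binding (a lower number here means a stronger inhibitor, a higher number a weaker inhibitor), compound 2 gives 7 nM, whereas compound 1 `CCC(CC)(c1nnc[nH]1)c1ccc(-c2ccc3cc(F)cc(F)c3c2)[nH]c1=O` gives 89 nM. Compound 3 `CC(C)NC(=O)CC(c1ccc(-c2ccc3cccc(F)c3c2)[nH]c1=O)C(C)C` differs from compound 2 in a single place: (isopropylcarbamoyl)methyl in place of 4,5-dimethyl-1H-imidazol-2-yl on a saturated chain carbon bound to an aromatic carbon and a saturated chain carbon. Among the measured compounds shown here, no measured pair shows a change of this kind, so its effect cannot be read from the data. Weaker binding is expected for compound 3, with an estimated step of an 8.6-fold higher number from compound 2 to compound 3 (0.93 log units; beyond the scatter) that lies beyond the scatter. Compound 3 is thus expected to give 60 nM, within a range from 10 nM to 400 nM.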

Compound 3, inhibition constant: 5.8 nM
Compound 3: the middle estimate sits 10-fold (1.01 log units) above what was measured, and the stated range ends above it.
By their numbers in this assay, from the lowest: compounds 3 and 2 (each within the scatter of the next); then compound 1.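

Measured in this assay this swap is a 1.2-fold lower number from compound 2 to compound 3 (0.08 log units; within the scatter) and so leaves the number unchanged within the scatter. On this saturated chain carbon of the shared core, then, the open (isopropylcarbamoyl)methyl chain matches the ring of 4,5-dimethyl-1H-imidazol-2-yl, showing that in this pair a five-membered aromatic ring at this place is not needed for a low number. No measurement at hand bears on why the two groups read alike. The compounds shown leave open whether the amide hydrogen matters here. From the compounds shown here alone, how a carboxylic acid or a longer chain at this carbon would read also stays unknown.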